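The source may hold more compounds than are shown below. What is called first, only, known or untested is meant among the compounds shown, and "the series" means these compounds.

Measured so far:
Compound 1, `CC1(OC(=O)N2CCC(O[C@H]3CC[C@H](Oc4cnc(S(C)(=O)=O)cn4)CC3)CC2)CC1`, in a functional assay on isolated protein for agonist activity at Glucose-dependent insulinotropic receptor (Homo sapiens), read by HTRF and cAMP accumulation (a lower number here means a smaller maximal response, a higher number a larger maximal response), gives 118%.
Compound 2, `C[C@H](CF)OC(=O)N1CCC(O[C@H]2CC[C@H](Oc3cnc(S(C)(=O)=O)cn3)CC2)CC1`, in this assay gives 108%.

Going by the values given here, compound 2 stands lowest of the two numbers known, and its nearest neighbour is compound 1, since a number 10 percentage points lower from compound 1 to compound 2 (within the scatter), a step that lies within the scatter. Compound 3, `C[C@@H](CF)OC(=O)N1CCC(O[C@H]2CC[C@H](Oc3cnc(S(C)(=O)=O)cn3)CC2)CC1`, has not yet been measured. Compared with compound 2, (the two compounds have the same atoms and bonds and differ only in configuration as drawn: 2 of 3 stereo elements differ; a stereocentre at a saturated chain carbon is drawn R in compound 2 and S in compound 3; a stereocentre at a saturated ring carbon is drawn R in compound 2 and S in compound 3). Among the compounds with values here, none of the measured steps concerns a change of configuration alone; the only step available, a number 10 percentage points lower from compound 1 to compound 2 (within the scatter), exchanges one group for another and is itself within the scatter. Within the data shown here, with no step of this kind to draw on, compound 3 is expected to show at most a change of the size no change at the digits printed from compound 2 to compound 3 (within the scatter), that is, nothing beyond the scatter. Compound 3 is therefore estimated at 108%, with a range from 85% to 125%.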

Compound 3, largest response reached (Emax), in percent of the reference or control that the assay uses: 105%
Estimate against measurement, compound 3: 3 percentage points above; measured number inside the range.
By their numbers in this assay, from the lowest: compounds 3, 2 and 1 (each within the scatter of the next, the first and the last beyond it).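

In this assay the change of configuration alone gives a number 3 percentage points lower from compound 2 to compound 3 (within the scatter), so at this position the drawn configuration shows no effect on the maximal response that can be told from the scatter, and the pair's comparison rests on one fact: the fact that compounds 2 and 3 differ only in the configuration as drawn. The exchange of 1-methylcyclopropyl for 1-(fluoromethyl)ethyl on an oxygen next to a carbonyl group, which stayed within the scatter in the earlier pair, now gives a number 13 percentage points lower from compound 1 to compound 3 (beyond the scatter), a modest step. That step holds for only one of the two drawn forms, so it shows how little separates the group exchange from the scatter.

Going by these compounds, two stereo elements differ together between compound 2 and compound 3, so the contribution of each remains open. Also open, on these data alone, is how the maximal response would respond to a longer chain or a benzyl group on that oxygen.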